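The compounds below may be only part of what the source reports. "The series", "measured", "known", "first", "only" and "open" are said of these compounds alone.

Working notes on the series. Compound 1 `COc1ccc(/C=C/C(=O)c2cccs2)c(CN2CCCCC2)c1O` and compound 2 `COc1ccc(/C=C/C(=O)c2ccco2)c(CN2CCCCC2)c1O` share one core and differ only in the aromatic group on the carbonyl carbon. In a functional assay on KB cells (Homo sapiens) for cytotoxicity, read by sulforhodamine B assay, with a stated time of 3 days (on this read-out lower numbers stand for an effect already at smaller amounts and higher numbers for an effect only at larger amounts of compound), compound 1 gives 2.09 ug/mL. In this assay compound 2 gives 2.61 ug/mL. The step of a 1.2-fold higher number from compound 1 to compound 2 (0.10 log units; within the scatter) is the only measured one in the set. On the two numbers shown, compound 2 holds the higher value, with compound 1 its nearest neighbour within the scatter, so no order between them can be stated.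

Compound 3 `COc1ccc(/C=C/C(=O)c2cccnc2)c(CN2CCCCC2)c1O` differs from compound 2 in one place: pyridin-3-yl in place of furan-2-yl on a carbonyl carbon. Among the compounds with values here, the measured step of a 1.2-fold higher number from compound 1 to compound 2 (0.10 log units; within the scatter) bears on this change in that it also exchanges the aromatic group on the carbonyl carbon, and it stayed within the scatter; no measured step exchanges a five-membered ring for a six-membered one. For compound 3 the expected step in this assay is a 1.1-fold higher number from compound 2 to compound 3 (0.06 log units; within the scatter), with nothing beyond the scatter anticipated. The estimate for compound 3 is 3 ug/mL, ranging from 1.2 ug/mL to 7.5 ug/mL.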

Compound 3, half-maximal effective concentration: 2.64 ug/mL
Beside the measured number, compound 3's estimate is 1.1-fold (0.06 log units) above it; measured number inside the range.
By their numbers in this assay, from the lowest: compounds 1, 2 and 3 (each within the scatter of the next).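

The six-membered ring adds what the earlier pair could not show. In this assay, pyridin-3-yl in place of furan-2-yl on a carbonyl carbon gives a 1.0-fold higher number from compound 2 to compound 3 (0.00 log units; within the scatter), and pyridin-3-yl in place of thiophen-2-yl gives a 1.3-fold higher number from compound 1 to compound 3 (0.10 log units; within the scatter). At this position, then, all three aromatic groups lie within the scatter of one another, whether the ring is five-membered or six-membered and whichever of the three hetero atoms it holds, and nothing available explains this.

Open, on these data alone, is whether a group of another kind on the carbonyl carbon, such as a plain phenyl ring, a longer alkyl chain or a ring bearing a carboxylic acid, would move the number beyond the scatter. The compounds shown also say nothing about changes elsewhere on the shared core.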